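The source may report more compounds than this note shows. Statements on the series, on what has been measured and on what is new or still open speak of the compounds shown alone.

In a functional assay on the whole organism for inhibition, with Mus musculus as the target, at a dose of 30 mg/kg by the oral route (a higher number here means more inhibition at the dose given (going by the name of the read-out), a lower number less inhibition), compound 3 `O=C(NCCCOc1ccc2nc(O)ccc2c1)N(C1CC1)[C@H]1CC[C@H](O)CC1` gives 0%, the lowest number among the three measured compounds. Compound 1 `O=C(NCCCOc1ccc2nc(O)ccc2c1)N(C1CC1)[C@@H]1CCCCC[C@H]1O` gives 44%, and compound 2 `O=C(NCCCOc1ccc2nc(O)ccc2c1)N(C1CC1)[C@@H]1CCC[C@@H](O)C1` gives 20%; the steps of a number 44 percentage points lower from compound 1 to compound 3 (beyond the scatter) and a number 20 percentage points lower from compound 2 to compound 3 (beyond the scatter) are both beyond the scatter, as is a number 24 percentage points lower from compound 1 to compound 2 (beyond the scatter). Compound 4 `O=C(NCCCOc1ccc2nc(O)ccc2c1)N(C1CC1)[C@H]1CCCC[C@H]1O` carries the change (2-hydroxycyclohexyl in place of 4-hydroxycyclohexyl on an amide-type nitrogen). The step from 2-hydroxycycloheptyl to 4-hydroxycyclohexyl bears most directly on it, and the step from 3-hydroxycyclohexyl to 4-hydroxycyclohexyl points the same way. The expected step for compound 4 is therefore upward, a number 30 percentage points higher from compound 3 to compound 4 (beyond the scatter). The cycloheptyl ring of compound 1 is not restored, so the expected step is kept smaller than the reversal of a number 44 percentage points lower from compound 1 to compound 3 (beyond the scatter). Compound 4 is expected to give 30%, in a range of 10% to 50%.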

Compound 4, a percentage reported as inhibition, in the whole organism at one dose (the size of the read-out at that dose, not a potency): 100%
For compound 4 the middle estimate is 70 percentage points below the measured one; the measured number lies above the stated range.
By their numbers in this assay, from the lowest: compound 3; then compound 2; then compound 1; then compound 4.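

In this assay, 2-hydroxycyclohexyl on the amide-type nitrogen gives a number 100 percentage points higher from compound 3 to compound 4 (beyond the scatter) and a number 80 percentage points higher from compound 2 to compound 4 (beyond the scatter), so with the same atoms, the placement of the hydroxyl on the six-membered ring governs this read-out. The 2-hydroxy pattern alone does not settle the outcome, as 2-hydroxycyclohexyl in place of 2-hydroxycycloheptyl gives a number 56 percentage points higher from compound 1 to compound 4 (beyond the scatter). Nothing available explains these steps.

Open, from the compounds shown here alone, is whether an amine or a methoxy group could stand in for the hydroxyl on the cyclohexyl ring. Other stereoisomers of 2-hydroxycyclohexyl also remain open.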